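Methyl removal on the five-membered ring of compound 1

This account rests on a few compounds, and the source may have more. Where it says the series, first, only, none or still open, it means among the compounds named here.

Measured so far:
compound 1 `Cc1nc(-c2c[nH]c3ccccc23)co1` gives 337000 nM
compound 2 `COc1ccc(-c2nc(-c3c[nH]c4ccccc34)co2)cc1OC` gives 359000 nM

Both numbers come from a functional assay on PC-3 cells (Homo sapiens) for cytotoxicity, read by MTT assay, with a stated time of 48 h; a lower number here means a stronger inhibitor, a higher number a weaker inhibitor. In this assay compound 1 gives 337000 nM and compound 2 gives 359000 nM. Compound 1 has the lower of the two numbers, but the gap to compound 2 is within the scatter, so the two compounds are treated as equal here and nothing is said about the aryl substituent that separates them.

Compound 3 `c1ccc2c(-c3cocn3)c[nH]c2c1` differs from compound 1 by hydrogen in place of methyl on an aromatic carbon. For the measured compounds named here, no pair of measured compounds shows this change, so the size of the step is not known from data. A small group is removed and both measured numbers already sit at the weak end of the range; the expected step from compound 1 to compound 3 is a 1.2-fold higher number from compound 1 to compound 3 (0.07 log units; within the scatter), none beyond the scatter. Compound 3 is therefore estimated at 400000 nM, with a range from 150000 nM to 1100000 nM.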

Compound 3, half-maximal inhibitory concentration: 321000 nM
Compound 3: middle estimate off by 1.2-fold (0.10 log units), on the high side; low and high end bracket the measured number.
By their numbers in this assay, from the lowest: compounds 3, 1 and 2 (each within the scatter of the next).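

In this assay, hydrogen in place of methyl on an aromatic carbon of the five-membered ring gives a 1.0-fold lower number from compound 1 to compound 3 (0.02 log units; within the scatter). For the compounds shown here, this is the first direct reading of this position: on this pair, the methyl can leave without a step beyond the scatter, so the read-out does not depend on that single carbon. No available evidence bears on this result.

As far as these compounds go, whether this position can move the number at all remains open, since an amine, a carboxylic acid or a longer chain such as propyl on the same carbon could give a different reading from hydrogen or methyl. From the compounds shown here alone, the effect of a fluorine or a hydroxyl on the group of 9 heavy atoms, at the other end of the shared core, is also open.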